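Working notes: carboxy for nitro on compound 2

A few compounds are considered here, and "the series" means these few. Any claim that something is new, unique, unknown or untested is made for them only; others in the source may bear on it.

In a functional assay on DU-145 cells (Homo sapiens) for inhibition, read by trypan blue exclusion, with a stated time of 96 h (on this read-out higher numbers stand for weaker inhibition of growth and lower numbers for stronger inhibition of growth), compound 2 (`O=C(/C(=C\c1ccc([N+](=O)[O-])c(O)c1)SCc1ccc(Br)cc1)c1ccc([N+](=O)[O-])cc1`) gives 1000 nM and stands level with compound 3 (`COc1ccccc1/C=C(\C(=O)c1ccc(Cl)cc1)S(=O)(=O)c1ccc(C)cc1`) at 1000 nM as the lower pair of the three numbers. Compound 1 (`O=C(/C(=C\c1ccc(Cl)cc1)S(=O)(=O)c1ccc(Br)cc1)c1ccc(Br)cc1`) gives 50000 nM in the same read-out, the highest of the three numbers and well clear of that pair.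

Compound 4 (`O=C(O)c1ccc(C(=O)/C(=C\c2ccc([N+](=O)[O-])c(O)c2)SCc2ccc(Br)cc2)cc1`) departs from compound 2 at one place: carboxy in place of nitro on an aromatic carbon with carboxy in place of nitro on an aromatic carbon. Among the compounds with values here, no measured pair shows this change, so the direction is a working expectation and the range stays wide. The expected 4.0-fold higher number from compound 2 to compound 4 (0.60 log units; beyond the scatter) is upward, toward weaker inhibition of growth, and beyond the scatter. In this assay the estimated value for compound 4 is 4000 nM (range 1000 nM to 20000 nM).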

Compound 4, concentration for 50% growth inhibition: 10000 nM
Beside the measured number, compound 4's estimate is 2.5-fold (0.40 log units) below it; the measured number falls inside the stated range.
By their numbers in this assay, from the lowest: compounds 2 and 3 (each within the scatter of the next); then compound 4; then compound 1.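

In this assay, within the data shown here, changing 4-nitrophenyl to 4-carboxyphenyl gives a 10-fold higher number from compound 2 to compound 4 (1.00 log units; beyond the scatter) as the only step that differs in one place. This position is therefore not indifferent to its substituent, and growth inhibition weakens when carboxy replaces nitro. The shown compounds leave open whether a methyl ester, a primary amide or an amine here would stay near compound 4 or return toward compound 2. One step also cannot show whether the same change would act alike on the cores of compound 1 or compound 3. No supporting data bear on why this step occurs.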